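This account rests on a few compounds, and the source may have more. Where it says the series, first, only, none or still open, it means among the compounds named here.

Compound 2 `CN(C)c1ccc(C2CC(c3ccc(-n4cncn4)cc3)=NN2C(=O)CCCl)cc1` and compound 1 `CC(=O)N1N=C(c2ccc(-n3cncn3)cc2)CC1c1ccc(N(C)C)cc1` share one core and differ only in the group on the carbonyl carbon. In a functional assay on MDA-MB-231 cells (Homo sapiens) for inhibition, read by sulforhodamine B assay, tested at 10 uM (a lower number here means less inhibition, a higher number more inhibition at the concentration tested (going by the name of the read-out)), compound 2 gives 3.7%, and compound 1 gives 7.4%. The two numbers lie within the scatter of each other; the step of a number 3.7 percentage points lower from compound 1 to compound 2 (within the scatter) shows this. Compound 3 `CN(C)c1ccc(C2CC(c3ccc(-n4cncn4)cc3)=NN2C(=O)c2ccc(F)cc2)cc1` differs from compound 2 by 4-fluorophenyl in place of 2-chloroethyl on a carbonyl carbon. Going by the values given here, the single measured step also touched the carbonyl carbon and stayed within the scatter, so for compound 3 no step beyond the scatter is expected, a number 3.3 percentage points higher from compound 2 to compound 3 (within the scatter). Compound 3 is therefore estimated at 7%, between -6% and 24%.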

Compound 3, a percentage reported as inhibition, at one concentration (the size of the read-out at that concentration, not a potency): 12.5%
Compound 3: the middle estimate sits 5.5 percentage points below what was measured, and the stated range covers the measured number.
By their numbers in this assay, from the lowest: compounds 2, 1 and 3 (each within the scatter of the next).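

With 4-fluorophenyl on the carbonyl carbon, the steps are a number 8.8 percentage points higher from compound 2 to compound 3 (within the scatter) and a number 5.1 percentage points higher from compound 1 to compound 3 (within the scatter) in this assay and so a six-membered aromatic ring at this place gives no step beyond the scatter. Methyl, 2-chloroethyl and 4-fluorophenyl, on a carbonyl carbon with an amide-type nitrogen in a ring, thus all lie within the scatter of one another. No measurement at hand offers an explanation for these numbers. As far as these compounds go, whether a carboxylic acid, an amine or a longer chain at this place would give a step beyond the scatter remains open.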